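Chloro for bromo on the phenyl of compound 2

A few compounds are considered here, and "the series" means these few. Any claim that something is new, unique, unknown or untested is made for them only; others in the source may bear on it.

Measured in an assay on isolated protein for inhibition of Calpain-1 catalytic subunit (Sus scrofa), read by FRET; a higher number here means a weaker inhibitor, a lower number a stronger inhibitor:
compound 1 `O=C(O)/C(S)=C/c1c[nH]c2cc(Cl)ccc12` — compound 1 gives 210 nM
compound 2 `O=C(O)/C(S)=C/c1cccc(Br)c1` — compound 2 gives 4000 nM

Among the measured compounds shown here, of the two numbers known in this assay, compound 2 holds the higher one; the gap to compound 1 is beyond the usual scatter, so compound 1 is the stronger inhibitor of the pair. For the measured compounds named here, no single-point step between measured compounds is available.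

Compound 3 `O=C(O)/C(S)=C/c1cccc(Cl)c1` is the next entry, differing from compound 2 only in the halogen: chloro in place of bromo on an aromatic carbon. The change is one halogen for another of the same kind of placement and size class, with no donor, acceptor or charge added or removed. Such a swap is expected to move this assay little, if at all, and no step beyond the scatter is expected from compound 2 to compound 3 a 1.1-fold higher number from compound 2 to compound 3 (0.05 log units; within the scatter). Compound 3 is therefore estimated at 4500 nM, within a range of 2000 nM to 10000 nM.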

Compound 3, half-maximal inhibitory concentration: 4200 nM
The estimate for compound 3 lay 1.1-fold (0.03 log units) above the measured number; low and high end bracket the measured number.
By their numbers in this assay, from the lowest: compound 1; then compounds 2 and 3 (each within the scatter of the next).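

Chloro in place of bromo on an aromatic carbon, meta to a group of 6 heavy atoms, gives a 1.1-fold higher number from compound 2 to compound 3 (0.02 log units; within the scatter) in this assay. Among the compounds shown here, this is the first single-point step, and it shows that the two halogens cannot be told apart at this position in this read-out. No measurement at hand bears on the reason for this result. 

Only these two halogens are shown at this position, so it remains open how an unsubstituted carbon, a methoxy group, an amine or a nitrile would read there. Compound 1 gives 210 nM but differs from compound 3 in more than one place, which leaves open which part of its structure goes with that value.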